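Phenoxymethyl for phenyl: a change expected to stay small

A few compounds are considered here, and "the series" means these few. Any claim that something is new, unique, unknown or untested is made for them only; others in the source may bear on it.

Of the compounds shown here, three built on one shared core have numbers so far in a functional assay on A549 cells (Homo sapiens) for cytotoxicity, read by MTT assay (a higher number here means a weaker inhibitor, a lower number a stronger inhibitor), for now. Compound 1 (`CCn1cc(-c2nnc(COc3ccc4ccccc4c3)o2)c(=O)c2cc(F)c(N3CCNCC3)cc21`) gives 80.2 ug/mL there. Compound 2 (`CCn1cc(-c2nnc(-c3ccccc3)o2)c(=O)c2cc(F)c(N3CCNCC3)cc21`) gives 112 ug/mL there. Compound 3 (`CCn1cc(-c2nnc(-c3ccc(Nc4ccccc4)cc3)o2)c(=O)c2cc(F)c(N3CCNCC3)cc21`) gives 88.6 ug/mL there. Compound 2 is not truly separated from either of the other two, as its steps to both lie within the scatter of repeat measurements.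

The unmeasured compound 4 (`CCn1cc(-c2nnc(COc3ccccc3)o2)c(=O)c2cc(F)c(N3CCNCC3)cc21`) carries phenoxymethyl in place of phenyl on an aromatic carbon and is otherwise the same as compound 2. The closest evidence is a 1.4-fold higher number from compound 1 to compound 2 (0.15 log units; within the scatter) where phenyl replaces ((naphthalen-2-yl)oxy)methyl on that carbon, a swap resembling the new one run in reverse. A second, looser guide is a 1.3-fold lower number from compound 2 to compound 3 (0.10 log units; within the scatter) where anilino stands in place of hydrogen on the phenyl group. Neither change moved the number beyond the scatter, so no step beyond the scatter is expected in this assay for this swap either, and no direction can be claimed. The expected step is a 1.1-fold lower number from compound 2 to compound 4 (0.06 log units; within the scatter) and it should be too small to read as real. For compound 4 the estimate is 98 ug/mL with an expected range from 65 ug/mL to 140 ug/mL for the eventual measurement.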

Compound 4, half-maximal inhibitory concentration: 76.8 ug/mL
Compound 4: the middle estimate sits 1.3-fold (0.11 log units) above what was measured; the measured number falls inside the stated range.
By their numbers in this assay, from the lowest: compounds 4, 1, 3 and 2 (each within the scatter of the next).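

In this assay, the carbon of the five-membered ring now carries a ring held out through a methylene and an oxygen rather than a phenyl attached directly, and this brings a 1.5-fold lower number from compound 2 to compound 4 (0.16 log units; within the scatter). So this swap, which adds two heavy atoms and a hydrogen-bond acceptor, leaves no readable mark on the number. Among these compounds, compound 4 also adds a comparison the earlier compounds could not give: with the oxymethyl link held constant, the far ring alone changes, and a 1.0-fold lower number from compound 1 to compound 4 (0.02 log units; within the scatter) shows that a naphthalen-2-yl and a phenyl on that oxygen cannot be told apart here. Together, these steps extend the flat picture from compounds 1, 2 and 3, since neither a change of link nor a change of ring size on the link separates any of the compounds joined by these steps.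

As far as these compounds go, an amine or a carboxylic acid at this carbon, or a longer chain in place of phenoxymethyl, remains open as a test of whether anything here can move the number beyond the scatter. Nothing available explains why these changes leave the number so little altered.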